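The source may hold more compounds than are shown below. What is called first, only, known or untested is meant among the compounds shown, and "the series" means these compounds.

In a functional assay on HeLa cells (Homo sapiens) for antiproliferative activity, read by MTT assay, with a stated time of 24 h (on this read-out lower numbers stand for an effect already at smaller amounts and higher numbers for an effect only at larger amounts of compound), compound 1 `CSc1ccc(/C(=N\O)c2cccc3ccccc23)cc1` gives 18000 nM. Compound 3 `CSc1ccc(/C(=N\OCCCCN2CCCCC2)c2cccc3ccccc23)cc1` gives 18000 nM, level with compound 1 at the digits shown. Compound 2 `CCN(CC)C(=O)CO/N=C(\c1ccc(SC)cc1)c1cccc2ccccc12` gives 25000 nM, within the scatter of compound 1. Compound 4 `CSc1ccc(/C(=N\OCCCCN2CCCC2)c2cccc3ccccc23)cc1` has not yet been measured. It carries 4-(pyrrolidin-1-yl)butyl in place of hydrogen on an oxygen of compound 1 (4-(pyrrolidin-1-yl)butyl in place of hydrogen on an oxygen). Two measured steps make the same kind of replacement on that oxygen. With 4-(piperidin-1-yl)butyl, the closest match, the result is no change at the digits printed from compound 1 to compound 3 (within the scatter). With (diethylcarbamoyl)methyl, it is a 1.4-fold higher number from compound 1 to compound 2 (0.14 log units; within the scatter). Neither leaves the scatter, so no step beyond the scatter is expected in this assay. The expected result is no change at the digits printed from compound 1 to compound 4 (within the scatter). Compound 4 is estimated at 18000 nM, within a range of 9000 nM to 36000 nM.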

Compound 4, half-maximal effective concentration: > 50000 nM
Compound 4: no number, only a limit; the forecaster's own chance of this, stated with the estimate: 5%; middle value at least 2.7-fold (0.44 log units) away from the limit.
By their numbers in this assay, from the lowest: compounds 1, 3 and 2 (each within the scatter of the next). At a limit, above all of these: compound 4.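

Compound 4 has only a limit, not a number: the limit of > 50000 nM in this assay, at which 1 of the 4 values shown sits. Going from hydroxy to 4-(pyrrolidin-1-yl)butoxy brings an at least 2.7-fold higher number from compound 1 to compound 4 (0.44 log units; beyond the scatter), and exchanging piperidin-1-yl for pyrrolidin-1-yl brings an at least 2.7-fold higher number from compound 3 to compound 4 (0.44 log units; beyond the scatter), so the earlier sign that this oxygen tolerates any substituent no longer holds, and the ring at the chain end matters. The comparison with the diethylcarbamoyl compound is less clear, giving an at least 2.0-fold higher number from compound 2 to compound 4 (0.30 log units; that floor lies within the scatter).

From the compounds shown here alone, it remains open how far compound 4 truly lies from the others. Also open, going by these compounds, is whether morpholin-4-yl on the same butyl chain, or pyrrolidin-1-yl on a longer chain, would stay level with compound 1.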